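A few compounds are considered here, and "the series" means these few. Any claim that something is new, unique, unknown or untested is made for them only; others in the source may bear on it.

In a functional assay on SK-MEL-28 cells (Homo sapiens) for cytotoxicity, read by CCK-8 assay, with a stated time of 24 h (a higher number here means a weaker inhibitor, a lower number a stronger inhibitor), compound 1 `COc1ccccc1Oc1c(N)nc(-c2ccc(C)cc2)nc1OCCO` gives 6190 nM, and compound 2 `COc1ccccc1Oc1c(N)nc(-c2ccc(F)cc2)nc1OCCO` gives 20100 nM, the higher of the two numbers. Compound 3 `COc1ccccc1Oc1c(N)nc(-c2cccc(Cl)c2)nc1OCCO` carries 3-chlorophenyl in place of 4-fluorophenyl on an aromatic carbon of the shared core: 3-chlorophenyl in place of 4-fluorophenyl on an aromatic carbon. For the measured compounds named here, only one measured step bears on this change, the modest 3.2-fold higher number from compound 1 to compound 2 (0.51 log units; beyond the scatter), which replaces a group on the same phenyl ring. Going by the values given here, no measured compound carries 3-chlorophenyl, so the expectation is loose. The estimated change, a 2.2-fold lower number from compound 2 to compound 3 (0.35 log units; beyond the scatter), is of similar modest size, toward a lower number. Compound 3 is estimated at 9000 nM, within a range of 3500 nM to 22000 nM.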

Compound 3, half-maximal inhibitory concentration: 4170 nM
Compound 3: middle estimate off by 2.2-fold (0.33 log units), on the high side, and the stated range covers the measured number.
By their numbers in this assay, from the lowest: compounds 3 and 1 (each within the scatter of the next); then compound 2.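

The change from 4-fluorophenyl to 3-chlorophenyl gives a 4.8-fold lower number from compound 2 to compound 3 (0.68 log units; beyond the scatter), so a halogen on this phenyl ring does not by itself bring the higher number. Set against 4-methylphenyl, 3-chlorophenyl gives a 1.5-fold lower number from compound 1 to compound 3 (0.17 log units; within the scatter), so these two groups cannot be told apart in this assay. Nothing available explains the difference between the groups. The compounds shown leave open whether the identity of the halogen or its place on the phenyl ring accounts for the step, which 4-chlorophenyl would help separate. From the compounds shown here alone, how an amine or a carboxylic acid on that ring would read also remains open.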